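Removing a Methyl from a Fused Heteroaromatic Core

A few compounds are considered here, and "the series" means these few. Any claim that something is new, unique, unknown or untested is made for them only; others in the source may bear on it.

Measured compounds:
- compound 1, `Cc1ccnc2nc(-c3ccc(F)cc3)cc(O)c12`, 2880 nM
- compound 2, `COc1ccccc1-c1cc(O)c2cc(C)cnc2n1`, 3020 nM
- compound 3, `Cc1cnc2nc(-c3ccc(F)cc3)cc(O)c2c1`, 2630 nM

Of the compounds shown here, three sharing a fused two-ring core have been measured in a functional assay on MDA-MB-435 cells (Homo sapiens); on this read-out higher numbers stand for weaker inhibition of growth and lower numbers for stronger inhibition of growth. Compound 1 gives 2880 nM, compound 3 gives 2630 nM, and compound 2 gives 3020 nM. Compound 2 carries the highest number of the three, but its gaps to compound 1 and to compound 3 both lie within the usual scatter of repeated measurements, so the three cannot be ranked against each other on these numbers alone.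

Compound 4, `COc1ccccc1-c1cc(O)c2cccnc2n1`, has not yet been measured. It differs from compound 2 in one place: hydrogen in place of methyl on an aromatic carbon. Among the compounds with values here, nothing among the measured compounds shows what removing this methyl does, since no pair of them differs in only that way.

With no such comparison available, the expectation is a step from compound 2 to compound 4 of a 1.2-fold higher number from compound 2 to compound 4 (0.08 log units; within the scatter), that is, no change beyond the scatter, perhaps leaning toward a somewhat higher number. Compound 4 is therefore expected to give about 3600 nM, with a range from 1500 nM to 9000 nM.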

Compound 4, concentration for 50% growth inhibition: 39800 nM
Compound 4: middle estimate off by 11-fold (1.04 log units), on the low side; measured number above the stated range.
By their numbers in this assay, from the lowest: compounds 3, 1 and 2 (each within the scatter of the next); then compound 4.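

In this assay, hydrogen in place of methyl on this aromatic carbon, two atoms from the ring nitrogen, gives a 13-fold higher number from compound 2 to compound 4 (1.12 log units; beyond the scatter), so compound 2, which keeps the methyl, inhibits growth much more strongly than compound 4. Within the data shown here, the earlier numbers lay within the scatter of one another and included no pair differing only at this carbon, so they could not show that this position matters so much for growth inhibition. Here the change is small in structural terms: one heavy atom leaves, with no ring, hydrogen-bond donor, hydrogen-bond acceptor or net charge involved, yet the read-out moves far beyond the scatter. Nothing presented here explains the size of this step.

From the compounds shown here alone, it remains open whether an ethyl group, a chlorine atom or a methoxy group on this carbon would match the methyl, or whether the result depends on methyl itself. Going by these compounds, it is also open whether replacing the methyl with hydrogen would produce a step of similar size in compound 3, which carries a methyl on the same carbon but has a fluorophenyl group instead of a methoxyphenyl group.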